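Replacing an Aromatic Ketone Group with a Cyclopropyl Ketone

This account rests on a few compounds, and the source may have more. Where it says the series, first, only, none or still open, it means among the compounds named here.

In a functional assay on PC-3 cells (Homo sapiens) for inhibition, read by MTT assay, with a stated time of 48 h (a lower number here means a stronger inhibitor, a higher number a weaker inhibitor), compound 1 `COc1ccc(CSc2nnc(-c3cc(OC)c(OC)c(OC)c3)n2-c2ccc(N(C)C)cc2)cc1` gives > 60000 nM, which is a limit of the assay and not a number. Compound 2 `COc1cc(-c2nnc(SCc3ccc(F)cc3)n2-c2ccc(N(C)C)cc2)cc(OC)c1OC` gives 46500 nM. Compound 3 `COc1ccc(C(=O)CSc2nnc(-c3cc(OC)c(OC)c(OC)c3)n2-c2ccc(N(C)C)cc2)cc1` gives 22000 nM, the lower of the two actual numbers.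

The next structure, compound 4 `COc1cc(-c2nnc(SCC(=O)C3CC3)n2-c2ccc(N(C)C)cc2)cc(OC)c1OC`, has cyclopropyl in place of 4-methoxyphenyl on a carbonyl carbon. The carbonyl itself stays. Two measured steps bring in that carbonyl group: an at least 2.7-fold lower number from compound 1 to compound 3 (0.43 log units; beyond the scatter), and a 2.1-fold lower number from compound 2 to compound 3 (0.33 log units; beyond the scatter). Both are modest, the first possibly larger. A third step, an at least 1.2-fold lower number from compound 1 to compound 2 (0.11 log units; that floor lies within the scatter), swaps fluoro for methoxy on an aromatic carbon. Among the compounds with values here, no measured step changes the group on the carbonyl carbon, which leaves this expectation loosely anchored. It rests on compound 3 at 22000 nM, whose carbonyl compound 4 retains. The expected change in this assay is a 1.4-fold higher number from compound 3 to compound 4 (0.13 log units; within the scatter), a small rise at most and nothing beyond the scatter. Compound 4 is estimated at 30000 nM, with an expected range of 11000 nM to 60000 nM.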

Compound 4, half-maximal inhibitory concentration: 45900 nM
The estimate for compound 4 lay 1.5-fold (0.18 log units) below the measured number; low and high end bracket the measured number.
By their numbers in this assay, from the lowest: compound 3; then compounds 4 and 2 (each within the scatter of the next). At a limit, above all of these: compound 1.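

In this assay, the group on the carbonyl carbon makes a difference of its own: with the carbonyl kept, cyclopropyl in place of 4-methoxyphenyl gives a 2.1-fold higher number from compound 3 to compound 4 (0.32 log units; beyond the scatter). The second step reads a 1.0-fold lower number from compound 2 to compound 4 (0.01 log units; within the scatter), so the carbonyl alone does not carry the lower number of compound 3, and cyclopropylcarbonyl and 4-fluorophenyl on that saturated chain carbon cannot be told apart here. Compound 1 stands at a limit and not a number, which leaves only an at least 1.3-fold lower number from compound 1 to compound 4 (0.11 log units; that floor lies within the scatter): the limit of > 60000 nM in this assay, at which 1 of the 4 values shown sits.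

From the compounds shown here alone, what remains open is whether the aromatic ring or its methoxy group goes with the lower number of compound 3. The compounds shown also do not tell how a plain phenyl, a cyclohexyl or an amine on the carbonyl carbon would read.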